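Cyano in Place of Chloro: Expectation for Compound 4

This account rests on a few compounds, and the source may have more. Where it says the series, first, only, none or still open, it means among the compounds named here.

Three compounds sharing one core were tested in an assay (strain Sprague-Dawley) for inhibition of Amine oxidase [flavin-containing] A (Rattus norvegicus), read by spectrophotometry, with a stated time of 5 min; on this read-out higher numbers stand for weaker inhibition and lower numbers for stronger inhibition. Compound 1 `CNC(=O)/C=C1/COc2cc(OS(=O)(=O)c3ccccc3)ccc21` gives 34 nM. Compound 2 `CNC(=O)/C=C1/COc2cc(OS(=O)(=O)c3cccc(Cl)c3)ccc21`, which carries a chloro on an aromatic carbon, gives 41 nM. Compound 3 `CNC(=O)/C=C1/COc2cc(OS(=O)(=O)c3ccc(Cl)cc3)ccc21`, with its chloro on a different aromatic carbon, gives 12 nM and stands lowest of the three, with compound 1 nearest and compound 2 furthest. The steps of a 2.8-fold lower number from compound 1 to compound 3 (0.45 log units; beyond the scatter) and a 3.4-fold lower number from compound 2 to compound 3 (0.53 log units; beyond the scatter) show that the 4-chlorophenyl arrangement is what sets compound 3 apart, while a 1.2-fold higher number from compound 1 to compound 2 (0.08 log units; within the scatter) shows no change.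

Compound 4 `CNC(=O)/C=C1/COc2cc(OS(=O)(=O)c3ccc(C#N)cc3)ccc21` differs from compound 3 by cyano in place of chloro on an aromatic carbon. Within the data shown here, no measured step shows a cyano at this place, so the only bearing comes from the steps that placed the chloro there: its removal cost a modest amount in both. A cyano is expected to hold part of that gain, so the step of a 2.1-fold higher number from compound 3 to compound 4 (0.32 log units; beyond the scatter) is expected to be small and toward a higher number in this assay. Compound 4 is therefore estimated at 25 nM, within 10 nM to 70 nM.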

Compound 4, half-maximal inhibitory concentration: 45 nM
Compound 4: middle estimate off by 1.8-fold (0.26 log units), on the low side, within the range that was stated.
By their numbers in this assay, from the lowest: compound 3; then compounds 1, 2 and 4 (each within the scatter of the next).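

In this assay, exchanging chloro for cyano on this aromatic carbon, para to a large group, gives a 3.8-fold higher number from compound 3 to compound 4 (0.57 log units; beyond the scatter) and so does not keep the lower number seen with the chloro. Cyano in place of hydrogen gives a 1.3-fold higher number from compound 1 to compound 4 (0.12 log units; within the scatter) and the change from 3-chlorophenyl to 4-cyanophenyl gives a 1.1-fold higher number from compound 2 to compound 4 (0.04 log units; within the scatter) and neither step lies beyond the scatter, so among these four compounds only the 4-chlorophenyl group stands apart. Nothing available explains why chloro and cyano part here.

Open, going by these compounds, is whether any other group at this place, such as bromo, methyl, methoxy or an amine, would match the chloro or fall level with the cyano. Also open, on these data alone, is how a cyano on the aromatic carbon that carries the chloro in compound 2 would read.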